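Compound 3 to compound 4: cytotoxicity working notes

The compounds below may be only part of what the source reports. "The series", "measured", "known", "first", "only" and "open" are said of these compounds alone.

compound 1 `CCc1ccc(C(=O)/C=C/c2ccc3c(c2)B(O)OC3)cc1` gives > 10 ug/mL 
compound 2 `O=C(/C=C/c1ccc2c(c1)B(O)OC2)c1ccccn1` gives > 10 ug/mL 
compound 3 `O=C(/C=C/c1ccc2c(c1)B(O)OC2)c1ccco1` gives > 10 ug/mL 

In an ADME assay on L929 cells (Mus musculus) for cytotoxicity, read by resazurin assay, with a stated time of 72 h (on this read-out higher numbers stand for weaker inhibition and lower numbers for stronger inhibition), compound 3 gives > 10 ug/mL and this is a limit, not a number. The entries for compound 1 and compound 2 are limits as well. Compound 4 `O=C(/C=C/c1ccc2c(c1)B(O)OC2)c1ccccc1O` carries 2-hydroxyphenyl in place of furan-2-yl on a carbonyl carbon. Among the compounds with values here, the one measured step that bears on this change, also made on a carbonyl carbon, is a step that the two limits leave unreadable from compound 2 to compound 3 and it gives no size. All the evidence sits at one point (the limit of > 10 ug/mL in this assay, at which 3 of the 3 values shown sit) so no measured size carries over to compound 4. No step beyond the scatter is expected in this assay and no direction can be given, so the estimated step is a step that the limit leaves unreadable from compound 3 to compound 4 for now. For compound 4 the expected value is 14 ug/mL with an estimated range of 5 ug/mL to 30 ug/mL and a reading at the limit is the likeliest outcome.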

Compound 4, half-maximal inhibitory concentration: > 10 ug/mL
Compound 4 ended at the assay's limit; the forecaster's own chance of this, stated with the estimate: 70%; the middle value lies beyond the limit too.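

Within the data shown here, the entries for compound 2, compound 3 and compound 4 in this assay are all limits, so no step to compound 4 can be read from either compound. Whether any group on the carbonyl carbon changes the cytotoxicity read-out stays open, with every value at one point: the limit of > 10 ug/mL in this assay, at which 4 of the 4 values shown sit.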